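Cyclohexyl in place of vinyl: cytotoxicity expectation

The source may report more compounds than this note shows. Statements on the series, on what has been measured and on what is new or still open speak of the compounds shown alone.

Three compounds on the shared core carry a measurement in an ADME assay on MDCK cells (Canis lupus familiaris) for cytotoxicity, read by microscopy, with a stated time of 48 h; on this read-out lower numbers stand for higher toxicity in this test and higher numbers for lower toxicity in this test. Compound 1 `CCCc1csc(CN[C@@H]2C[C@H]3C[C@@H]([C@H]2C)C3(C)C)c1` gives 12500 nM in this assay. Compound 2 `C[C@H]1[C@H](NCc2cncnc2)C[C@H]2C[C@@H]1C2(C)C` reaches only the limit of this assay, > 100000 nM, which is the limit of > 100000 nM in this assay, at which 1 of the 3 values shown sits. Compound 3 `C=Cc1ccsc1CN[C@@H]1C[C@H]2C[C@@H]([C@H]1C)C2(C)C` gives 50000 nM, the highest of the two numbers reported; its nearest neighbour is compound 1, and that gap lies beyond the scatter.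

Compound 4 `C[C@H]1[C@H](NCc2sccc2C2CCCCC2)C[C@H]2C[C@@H]1C2(C)C` differs from compound 3 by cyclohexyl in place of vinyl on an aromatic carbon. Among the compounds with values here, no measured pair shows this change, so no step size is known. The step is expected to run toward a lower number, beyond the scatter, as an 8.3-fold lower number from compound 3 to compound 4 (0.92 log units; beyond the scatter). Compound 4 is estimated at 6000 nM in this assay, within a range from 2000 nM to 25000 nM.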

Compound 4, minimum cytotoxic concentration: 1560 nM
Estimate against measurement, compound 4: 3.8-fold (0.59 log units) above; measured number below the stated range.
By their numbers in this assay, from the lowest: compound 4; then compound 1; then compound 3. At a limit, above all of these: compound 2.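

Cyclohexyl in place of vinyl on this aromatic carbon, two ring bonds from the ring sulfur, gives a 32-fold lower number from compound 3 to compound 4 (1.51 log units; beyond the scatter) in this assay. This position is therefore not neutral to what it carries, and the change moves the read-out toward higher toxicity in this test. No measured property among the data accounts for the step.

This single pair cannot separate the effect of the ring from that of the added carbons or the lost double bond. A straight hexyl chain or an amine at this position would bear on that question.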